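Replacing the Cyclohexylmethyl Tail with Benzyloxy

The compounds below may be only part of what the source reports. "The series", "measured", "known", "first", "only" and "open" are said of these compounds alone.

Measured so far in an assay on CHO-K1 cells for displacement of a labelled ligand from prostaglandin E2 receptor EP1 subtype (Homo sapiens); on this read-out lower numbers stand for stronger inhibition and higher numbers for weaker inhibition:
compound 1, `Cc1cc(C(N)=O)nn1Cc1cc(Cl)ccc1OCc1ccccc1`, gives 126 nM
compound 2, `CC(=O)Nc1cc(C)n(Cc2cc(Cl)ccc2OCc2ccccc2)n1`, gives 316 nM
compound 3, `Cc1cc(NC(=O)CC2CCCCC2)nn1Cc1cc(Cl)ccc1OCc1ccccc1`, gives 6.31 nM

The three share one core and differ only in the group on an aromatic carbon. Compound 3 stands lowest of the three: the steps of a 20-fold lower number from compound 1 to compound 3 (1.30 log units; beyond the scatter) and a 50-fold lower number from compound 2 to compound 3 (1.70 log units; beyond the scatter) are both large, while a 2.5-fold higher number from compound 1 to compound 2 (0.40 log units; beyond the scatter) is modest and runs the other way. Compound 4, `Cc1cc(NC(=O)OCc2ccccc2)nn1Cc1cc(Cl)ccc1OCc1ccccc1`, is not yet measured. It differs from compound 3 by benzyloxy in place of cyclohexylmethyl on a carbonyl carbon. The two large steps that lead to compound 3 show that a bulky group on that carbonyl carbon goes with a much lower number; compound 2, whose chain carbon carries hydrogen instead of cyclohexyl, sits far higher. Among the measured compounds shown here, no measured step exchanges a saturated ring for an aromatic one, so the expectation rests on the comparable size of the entering group alone. Compound 4 is therefore expected to land near compound 3, with an expected step of a 1.9-fold higher number from compound 3 to compound 4 (0.28 log units; within the scatter). Compound 4 is estimated at 12 nM, within a range from 3 nM to 50 nM.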

Compound 4, half-maximal inhibitory concentration: 79.4 nM
Compound 4: middle estimate off by 6.6-fold (0.82 log units), on the low side; measured number above the stated range.
By their numbers in this assay, from the lowest: compound 3; then compounds 4 and 1 (each within the scatter of the next); then compound 2.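

In this assay, a large group on this carbonyl carbon is not enough on its own: benzyloxy, with its oxygen and aromatic ring, does far worse here than cyclohexylmethyl with its saturated ring (a 13-fold higher number from compound 3 to compound 4 (1.10 log units; beyond the scatter)). Benzyloxy still keeps part of the gain over methyl (a 4.0-fold lower number from compound 2 to compound 4 (0.60 log units; beyond the scatter)), so the size of the step depends on which large group is present. Set against the carbamoyl group, the (benzyloxycarbonyl)amino group shows no difference that can be told from the scatter (a 1.6-fold lower number from compound 1 to compound 4 (0.20 log units; within the scatter)).

No measurement shown here gives a reason for the loss on going to benzyloxy. Still open, as far as these compounds go, is whether the oxygen or the aromatic ring accounts for it, which phenethyl or cyclohexylmethoxy on the same carbonyl carbon would help to separate.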